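Swapping the aryl ketone substituent in a hydroxamic acid pair

The compounds below may be only part of what the source reports. "The series", "measured", "known", "first", "only" and "open" are said of these compounds alone.

compound 1 `Cn1cc(/C=C/C(=O)c2ccccc2)cc1/C=C/C(=O)NO`: 260 nM
compound 2 `Cn1cc(/C=C/C(=O)c2ccc(F)cc2)cc1/C=C/C(=O)NO`: 24900 nM

Among the measured compounds shown here, in an assay on isolated protein for inhibition of histone deacetylase HD1B (Zea mays) (on this read-out lower numbers stand for stronger inhibition and higher numbers for weaker inhibition), compound 2 gives the higher of the two numbers measured so far, and the single measured step leads to it: a 96-fold higher number from compound 1 to compound 2 (1.98 log units; beyond the scatter). Compound 3 `Cc1cccc(C(=O)/C=C/c2cc(/C=C/C(=O)NO)n(C)c2)c1` carries 3-methylphenyl in place of 4-fluorophenyl on a carbonyl carbon. That measured step bears on the fluorine part of the change, and it was large, so taking the fluorine away again may return part of it. For the measured compounds named here, no measured step covers the methyl part. The step of a 17-fold lower number from compound 2 to compound 3 (1.22 log units; beyond the scatter) is therefore the expected one, downward but uncertain in size. Compound 3 is estimated at 1500 nM, within a range of 200 nM to 12000 nM.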

Compound 3, half-maximal inhibitory concentration: 2500 nM
Compound 3: the middle estimate sits 1.7-fold (0.22 log units) below what was measured, and the stated range covers the measured number.
By their numbers in this assay, from the lowest: compound 1; then compound 3; then compound 2.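

In this assay, the methyl change can now be read by itself: 3-methylphenyl in place of phenyl gives a 9.6-fold higher number from compound 1 to compound 3 (0.98 log units; beyond the scatter) and so also weakens inhibition. Yet this ring is clearly better tolerated than 4-fluorophenyl, with a 10-fold lower number from compound 2 to compound 3 (1.00 log units; beyond the scatter) recovering only part of the loss. Nothing available here explains these differences.

Compound 2 and compound 3 differ in both the substituent and its place on the ring, so these two effects cannot be separated. 3-Fluorophenyl and 4-methylphenyl would be the groups that could tell them apart.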